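The source may report more compounds than this note shows. Statements on the series, on what has been measured and on what is new or still open speak of the compounds shown alone.

In a functional assay on Hep 3B2 cells (Homo sapiens) for antiproliferative activity, read by MTT assay, with a stated time of 24 h (on this read-out higher numbers stand for weaker inhibition and lower numbers for stronger inhibition), three compounds sharing one core have been measured. Compound 1 (`Cc1ccc2nc(C(=O)Nc3c(F)cc(-c4cccc(F)c4)cc3F)c(C)c(C(=O)O)c2c1`) gives 31600 nM, compound 2 (`Cc1c(C(=O)Nc2c(F)cc(-c3cccc(F)c3)cc2F)nc2ccc(F)cc2c1C(=O)O`) gives 14700 nM, and compound 3 (`CCOc1ccc2nc(C(=O)Nc3c(F)cc(-c4cccc(F)c4)cc3F)c(C)c(C(=O)O)c2c1`) gives 5800 nM, the lowest number of the three. Compound 4 (`COc1ccc2nc(C(=O)Nc3c(F)cc(-c4cccc(F)c4)cc3F)c(C)c(C(=O)O)c2c1`) differs from compound 3 by hydrogen in place of methyl on a saturated chain carbon bound to an oxygen on an aromatic ring, turning ethoxy into methoxy. Among the compounds with values here, no measured step makes this exact change. The closest guides are a 5.4-fold lower number from compound 1 to compound 3 (0.74 log units; beyond the scatter) and a 2.5-fold lower number from compound 2 to compound 3 (0.40 log units; beyond the scatter), both modest, with ethoxy in place of methyl and of fluoro on an aromatic carbon. Only a small upward move is expected, within the usual scatter, and the estimated step is a 1.6-fold higher number from compound 3 to compound 4 (0.19 log units; within the scatter). Compound 4 is expected at 9000 nM, with an estimated range from 3500 nM to 22000 nM.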

Compound 4, half-maximal inhibitory concentration: 14300 nM
Compound 4: the middle estimate sits 1.6-fold (0.20 log units) below what was measured; measured number inside the range.
By their numbers in this assay, from the lowest: compound 3; then compounds 4 and 2 (each within the scatter of the next); then compound 1.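

Trimming ethoxy to methoxy is enough to move the number (a 2.5-fold higher number from compound 3 to compound 4 (0.39 log units; beyond the scatter)), so the outer carbon of this chain counts, and an oxygen on the aromatic carbon does not alone set the value. Methoxy also keeps a smaller edge over methyl (a 2.2-fold lower number from compound 1 to compound 4 (0.34 log units; beyond the scatter)) than ethoxy does, and it stays within the scatter of fluoro (a 1.0-fold lower number from compound 2 to compound 4 (0.01 log units; within the scatter)). No measurement shown gives a reason for this.

On these data alone, whether a longer chain such as propoxy or butoxy would lower the number further remains open. So does whether an amine on this aromatic carbon would match the ethoxy or the methoxy compound.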